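The compounds below may be only part of what the source reports. "The series", "measured", "known", "first", "only" and "open" are said of these compounds alone.

Working notes on the series. Compound 1 `Cc1cc(Cc2cccc(Cl)c2)c(=O)n(CC(=O)Nc2ccc(Br)cc2)n1` carries a 3-chlorobenzyl group on the shared core, compound 2 `Cc1cc(N)c(=O)n(CC(=O)Nc2ccc(Br)cc2)n1` an amino group, compound 3 `COc1ccc(Nc2cc(C)nn(CC(=O)Nc3ccc(Br)cc3)c2=O)cc1` a (4-methoxyphenyl)amino group. In a functional assay on HL-60 cells (Homo sapiens), read by calcium flux (on this read-out higher numbers stand for an effect only at larger amounts of compound and lower numbers for an effect already at smaller amounts), compound 1 reaches only the limit > 50000 nM. In this assay compound 2 also gives only the limit > 50000 nM. Compound 3 likewise stands at the limit > 50000 nM in this assay. The steps a step that the two limits leave unreadable from compound 1 to compound 2, a step that the two limits leave unreadable from compound 1 to compound 3 and a step that the two limits leave unreadable from compound 2 to compound 3 remain unreadable because of the limit of > 50000 nM in this assay, at which 3 of the 3 values shown sit. Compound 4 `COc1cccc(C(=O)Nc2cc(C)nn(CC(=O)Nc3ccc(Br)cc3)c2=O)c1` differs from compound 3 by (3-methoxyphenyl)carbonyl in place of 4-methoxyphenyl on a nitrogen on an aromatic ring. Among the compounds with values here, none of the measured steps reads on this change, so no shift beyond the scatter can be expected from them. Compound 4 is therefore estimated at 60000 nM (range 20000 nM to 200000 nM) in this assay, a step that the limit leaves unreadable from compound 3 to compound 4 expected to stay at the limit.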

Compound 4, half-maximal effective concentration: > 50000 nM
Compound 4 was reported as a limit (the forecaster's own chance of this, stated with the estimate: 85%); the middle value does not contradict the limit.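

The steps from compound 2 and from compound 3 to compound 4 cannot be read, because each pair ends at the same limit: the limit of > 50000 nM in this assay, at which 4 of the 4 values shown sit. The compounds shown leave open which group on the shared core, if any, gives a measurable effect in this assay.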